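A few compounds are considered here, and "the series" means these few. Any claim that something is new, unique, unknown or untested is made for them only; others in the source may bear on it.

Measured compounds in a functional assay on HeLa cells (Homo sapiens) for inhibition, read by MTT assay, with a stated time of 48 h; on this read-out lower numbers stand for stronger inhibition and higher numbers for weaker inhibition:
compound 1 `COc1ccc(NC(=O)/C=C/c2coc3cc(OC)ccc3c2=O)cc1` gives 13000 nM
compound 2 `COc1ccc(NC(=O)/C=C/c2coc3cc(O)ccc3c2=O)cc1` gives > 100000 nM, which is a limit of the assay and not a number

Compound 2 therefore stands at the limit of this assay, one of the two values of the series, (the limit of > 100000 nM in this assay, at which 1 of the 2 values shown sits). Going by the values given here, the one measured step, an at least 7.6-fold higher number from compound 1 to compound 2 (0.88 log units; beyond the scatter), concerns hydrogen in place of methyl on an oxygen on an aromatic ring of the shared core. Compound 3 `O=C(/C=C/c1coc2cc(O)ccc2c1=O)Nc1ccccc1` differs from compound 2 at a different place: hydrogen in place of methoxy on an aromatic carbon. Among the compounds with values here, no measured step touches this place, so the step from compound 1 to compound 2 gives no direct guide to it. Within the data shown here, what is known is only that compound 2 already sits at a limit in this assay. Compound 3 is expected to remain at or near that limit, an estimated step of a number no higher from compound 2 to compound 3 (the limit leaves the size open). The estimate for compound 3 is 100000 nM, within 30000 nM to 300000 nM, with a sizeable chance that only a limit is reported again.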

Compound 3, half-maximal inhibitory concentration: 9700 nM
Compound 3: the middle estimate sits 10-fold (1.01 log units) above what was measured; measured number outside the range, below it.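

In this assay, going by these compounds alone, the change from 4-methoxyphenyl to phenyl gives an at least 10-fold lower number from compound 2 to compound 3 (1.01 log units; beyond the scatter), so the place on the aromatic carbon, para to a large group, clearly bears on the read-out, which the earlier compounds could not show. The hydrogen on the oxygen of the shared core, which went with an at least 7.6-fold higher number from compound 1 to compound 2 (0.88 log units; beyond the scatter), is also present in compound 3, so that hydrogen alone does not hold a compound at the limit of the assay. The value of compound 2, > 100000 nM, is a limit and not a number, and the full size of the new step stays open: the limit of > 100000 nM in this assay, at which 1 of the 3 values shown sits.

Going by these compounds, whether the same change from 4-methoxyphenyl to phenyl moves the number in the same direction on the core of compound 1, with the methyl kept on the oxygen, remains open, so the two places cannot yet be read as independent of each other. Also open, on these data alone, is what a fluorine, an amine or a carboxylic acid would give at the place held by methoxy in compound 2 and by hydrogen in compound 3.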